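A few compounds are considered here, and "the series" means these few. Any claim that something is new, unique, unknown or untested is made for them only; others in the source may bear on it.

Three compounds have been measured in an ADME assay on HeLa Rh cells (Homo sapiens) for cytotoxicity, read by microscopy; on this read-out lower numbers stand for higher toxicity in this test and higher numbers for lower toxicity in this test:

compound 1, `COc1cc(CC(O)c2ccc(-c3cccc([N+](=O)[O-])c3)cc2)c([N+](=O)[O-])cc1OC`, gives 5500 nM in this test;
compound 2, `COc1cc(CC(O)c2ccc(-c3cccc(CO)c3)cc2)c([N+](=O)[O-])cc1OC`, gives 6000 nM;
compound 3, `COc1cc(CC(O)c2ccc(-c3ccccc3[N+](=O)[O-])cc2)c([N+](=O)[O-])cc1OC`, gives 9500 nM.

Compound 4, `COc1cc(CC(O)c2ccc(-c3ccccc3CO)cc2)c([N+](=O)[O-])cc1OC`, has not yet been measured.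

Compound 1 and compound 2 differ by hydroxymethyl in place of nitro on an aromatic carbon, and that exchange gave a 1.1-fold higher number from compound 1 to compound 2 (0.04 log units; within the scatter). Compound 3 and compound 4 differ by hydroxymethyl in place of nitro on an aromatic carbon. The two cores themselves differ by 2-nitrophenyl in place of 3-nitrophenyl on an aromatic carbon. The two exchanges are the same kind of change rather than the same one: in the first, the new group sits meta to a large group, in the second it sits ortho to a large group. For the measured compounds named here, since the only measured example of this change moved the number hardly at all, the step from compound 3 to compound 4 is expected to be small as well, about a 1.1-fold higher number from compound 3 to compound 4 (0.02 log units; within the scatter), resting on compound 1 and compound 2 alone. Compound 4 is therefore estimated to give about 10000 nM in this assay, between 5000 nM and 20000 nM.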

Compound 4, half-maximal cytotoxic concentration: 24000 nM
Beside the measured number, compound 4's estimate is 2.4-fold (0.38 log units) below it, and the stated range ends below it.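

In this assay, putting hydroxymethyl in place of nitro gave a 2.5-fold higher number from compound 3 to compound 4 (0.40 log units; beyond the scatter). Set beside the earlier case of the same exchange, this step cannot be told apart from it, so the data give no firm sign that the core alters what the exchange does: the same change on two cores in this assay, a 1.1-fold higher number (0.04 log units; within the scatter) from compound 1 to compound 2 and a 2.5-fold higher number (0.40 log units; beyond the scatter) from compound 3 to compound 4, 2.3-fold (0.36 log units) apart, within the scatter of two such steps. For the compounds shown here, this does not prove that the exchange carries over unchanged, as each core offers only one pair, and the larger steps, a 4.0-fold higher number from compound 2 to compound 4 (0.60 log units; beyond the scatter) and a 4.4-fold higher number from compound 1 to compound 4 (0.64 log units; beyond the scatter), show only that compound 4 has the highest number of the four, meaning the lowest toxicity in this test.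

The compounds shown carry only nitro or hydroxymethyl on this aromatic ring, so whether an amine or a carboxylic acid there would shift the number in the same way on either core remains open. Also open, as far as these compounds go, is how a longer chain, such as hydroxyethyl, would compare with hydroxymethyl.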